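The compounds below may be only part of what the source reports. "The series", "measured", "known", "first", "only" and "open" are said of these compounds alone.

For the measured compounds named here, compound 2 `COc1ccc(C2=C(c3cc(OC)c(OC)c(OC)c3)C(=O)C(O)C2)cc1` is the more potent of the two measured members. In an ADME assay on ECV-304 cells (Homo sapiens) for cytotoxicity, read by MTT assay, with a stated time of 72 h (a higher number here means a weaker inhibitor, a lower number a stronger inhibitor), compound 2 gives < 1 ug/mL, and that value is a limit of the assay rather than a number (the limit of < 1 ug/mL in this assay, at which 1 of the 2 values shown sits). Its comparator, compound 1 `C=CCOc1cc(C2=C(c3cc(OC)c(OC)c(OC)c3)C(=O)C(O)C2)ccc1OC`, carries an allyloxy group where compound 2 carries hydrogen. In this assay compound 1 gives > 100 ug/mL, which is also a limit rather than a number (the limit of > 100 ug/mL in this assay, at which 1 of the 2 values shown sits). The step of an at least 100-fold lower number from compound 1 to compound 2 (2.00 log units; beyond the scatter) is therefore large.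

Compound 3 `COc1ccc(C2=C(c3cc(OC)c(OC)c(OC)c3)C(=O)C(O)C2)cc1NC(=O)c1ccccc1` differs from compound 2 by benzamido in place of hydrogen on an aromatic carbon. Going by the values given here, the only measured step that bears on this change is an at least 100-fold lower number from compound 1 to compound 2 (2.00 log units; beyond the scatter), where a group was removed from an aromatic carbon; adding a group on an aromatic carbon in compound 3 points the other way. Compound 3 is therefore expected to give a weaker result, with the step of an at least 20-fold higher number from compound 2 to compound 3 (1.30 log units; beyond the scatter) estimated to go well beyond the scatter. The estimate for compound 3 in this assay is 20 ug/mL, within a range from 2 ug/mL to 100 ug/mL.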

Compound 3, half-maximal inhibitory concentration: > 100 ug/mL
Compound 3 was reported as a limit; the forecaster's own chance of this, stated with the estimate: 35%; at least 5.0-fold (0.69 log units) between middle value and limit.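

Putting benzamido in place of hydrogen, on the aromatic carbon ortho to a methoxy group and meta to a large group, gives an at least 100-fold higher number from compound 2 to compound 3 (2.00 log units; beyond the scatter) in this assay. Compound 3 gives > 100 ug/mL, which is a limit of the assay and not a number. This place on the ring now has a second group on record, and benzamido, with its extra aromatic ring and amide, ends at the same weak end of the assay as allyloxy, so among these three compounds only hydrogen gives the strong result, while the step between compound 1 and compound 3 cannot be read: the limit of > 100 ug/mL in this assay, at which 2 of the 3 values shown sit.

The compounds shown leave open whether any group at this place can keep the strong result of compound 2, for instance a hydroxyl, a fluorine atom or a plain amine, or whether hydrogen alone does so. They also leave open how allyloxy and benzamido truly rank against each other, since neither compound 1 nor compound 3 has a value that is an actual number.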